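Compound 3 and the step to compound 4

The compounds below may be only part of what the source reports. "The series", "measured", "known", "first", "only" and "open" are said of these compounds alone.

In a functional assay on the whole organism with Mus musculus as the target (on this read-out higher numbers stand for an effect only at larger amounts of compound and lower numbers for an effect already at smaller amounts), compound 1 `NC(=O)Cn1c(-c2ccc(Cl)cc2)nc2cccnc21` gives 4.1 mg/kg, compound 2 `NC(=O)Cn1c(-c2ccc(C(F)(F)F)cc2)nc2cccnc21` gives 11.7 mg/kg and compound 3 `O=C(Cn1c(-c2ccc(Cl)cc2)nc2cccnc21)N1CCCC1` gives 17.9 mg/kg. Compound 3 thus stands within the usual scatter of compound 2, and both lie clearly above compound 1. Compound 4 `O=C(Cn1c(-c2ccc(Cl)cc2)nc2cccnc21)Nc1cccnc1` keeps everything in compound 3 except the group on the carbonyl carbon, where (pyridin-3-yl)amino comes in place of pyrrolidin-1-yl: (pyridin-3-yl)amino in place of pyrrolidin-1-yl on a carbonyl carbon.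

Among the measured compounds shown here, one measured step bears directly on this place: a 4.4-fold higher number from compound 1 to compound 3 (0.64 log units; beyond the scatter), a modest step with pyrrolidin-1-yl in place of amino. The other, a 2.9-fold higher number from compound 1 to compound 2 (0.46 log units; beyond the scatter), is also modest, but it concerns trifluoromethyl in place of chloro on an aromatic carbon and says little about this change. For the measured compounds named here, the entering group, like the amino group of compound 1, carries the amide hydrogen, but no measured compound carries a ring on that nitrogen together with that hydrogen. The comparison is therefore loose, and only a lean towards a lower number is expected, without a firm step beyond the scatter. The expected step is a 1.6-fold lower number from compound 3 to compound 4 (0.21 log units; within the scatter). For compound 4 the estimate is 11 mg/kg, with an expected range from 4 mg/kg to 30 mg/kg.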

Compound 4, dose for half-maximal effect: 100 mg/kg
Estimate against measurement, compound 4: 9.1-fold (0.96 log units) below; measured number above the stated range.
By their numbers in this assay, from the lowest: compound 1; then compounds 2 and 3 (each within the scatter of the next); then compound 4.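

In this assay, among the compounds shown here, the group on the carbonyl carbon proves able to shift the number much further than the earlier compounds showed: (pyridin-3-yl)amino in place of pyrrolidin-1-yl gives a 5.6-fold higher number from compound 3 to compound 4 (0.75 log units; beyond the scatter), so the presence of the amide hydrogen in the entering group does not by itself bring the number back towards that of compound 1. Pyridin-3-yl in place of hydrogen on the amide-type nitrogen gives a 24-fold higher number from compound 1 to compound 4 (1.39 log units; beyond the scatter), the only step of this set that counts as large, and among the three compounds with chloro the number rises from amino through pyrrolidin-1-yl to (pyridin-3-yl)amino, each step beyond the scatter. Nothing available here accounts for the size of this rise.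

As far as these compounds go, whether a phenylamino or a methylamino group on the carbonyl carbon would stand nearer to compound 1 or to compound 4 remains open, and so does the share of the ring nitrogen in the result. From the compounds shown here alone, it is also open whether (pyridin-3-yl)amino would act in the same way alongside the trifluoromethyl group of compound 2.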